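Notes on the step from compound 3 to compound 4

The source may hold more compounds than are shown below. What is called first, only, known or untested is meant among the compounds shown, and "the series" means these compounds.

Values so far in an ADME assay on cells (Fibroblast) for cytotoxicity; a higher number here means a weaker inhibitor, a lower number a stronger inhibitor:
- compound 1 `O=C(/C=C/c1ccccc1)N[C@@H](CCCCCC(=O)NO)C(=O)Nc1cccc2cccnc12` gives 1240 nM
- compound 2 `O=C(CCCCC[C@H](NC(=O)c1ccc(Br)cc1)C(=O)NCc1ccccc1)NO` gives 5860 nM
- compound 3 `O=C(/C=C/c1ccccc1)N[C@@H](CCCCCC(=O)NO)C(=O)NCc1ccccc1` gives 4010 nM

Compound 3 (4010 nM) cannot be told apart from compound 2 on these numbers, while compound 1 (1240 nM) lies clearly lower than compound 3. The next compound is compound 4 `O=C(CCCCC[C@H](NC(=O)c1cc2ccccc2[nH]1)C(=O)NCc1ccccc1)NO`, which differs from compound 3 by 1H-indol-2-yl in place of 2-phenylethenyl on a carbonyl carbon and carries 1H-indol-2-yl in place of 2-phenylethenyl on a carbonyl carbon.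

The most relevant measured change sits on that same carbonyl carbon: a 1.5-fold lower number from compound 2 to compound 3 (0.16 log units; within the scatter), with 2-phenylethenyl in place of 4-bromophenyl. The other measured change, a 3.2-fold higher number from compound 1 to compound 3 (0.51 log units; beyond the scatter), puts benzyl in place of quinolin-8-yl on an amide-type nitrogen. It bears less directly, since compound 4 keeps the benzyl of compound 3. Going by the values given here, only one exchange at the carbonyl carbon has been measured, and no compound yet tested carries 1H-indol-2-yl, so the basis is thin. No step beyond the scatter is therefore expected in this assay. The estimated change is a 1.0-fold lower number from compound 3 to compound 4 (0.00 log units; within the scatter), in no clear direction. The estimated value for compound 4 is 4000 nM (expected range 1800 nM to 8500 nM).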

Compound 4, half-maximal inhibitory concentration: 1260 nM
For compound 4 the middle estimate is 3.2-fold (0.50 log units) above the measured one; the measured number lies below the stated range.
By their numbers in this assay, from the lowest: compounds 1 and 4 (each within the scatter of the next); then compounds 3 and 2 (each within the scatter of the next).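

In this assay, the group on the carbonyl carbon can clearly shift the number: a 3.2-fold lower number from compound 3 to compound 4 (0.50 log units; beyond the scatter), and a 4.7-fold lower number from compound 2 to compound 4 (0.67 log units; beyond the scatter). Going by these compounds alone, the one earlier exchange at this position could not separate the two groups involved, with a 1.5-fold lower number from compound 2 to compound 3 (0.16 log units; within the scatter), so 1H-indol-2-yl stands apart from both 2-phenylethenyl and 4-bromophenyl, while the earlier step beyond the scatter lay on the amide-type nitrogen, a 3.2-fold higher number from compound 1 to compound 3 (0.51 log units; beyond the scatter). The entering group differs from the leaving ones in its five-membered aromatic ring with 1 hetero atom and its hydrogen-bond donor, but these steps cannot assign the shift to either feature, and no measurement available here bears on a cause.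

The compounds shown leave open whether an amine or a carboxylic acid on a longer chain at the carbonyl carbon would shift the number in the same direction, and so whether the shift is specific to 1H-indol-2-yl. They also leave open whether 1H-indol-2-yl on the carbonyl carbon and quinolin-8-yl on the amide-type nitrogen would add up when carried by a single compound.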